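A Fluorine Added to the Compound with the Highest Number

This account rests on a few compounds, and the source may have more. Where it says the series, first, only, none or still open, it means among the compounds named here.

A set of three compounds sharing one core has been tested in a functional assay on the whole organism for inhibition, with Mus musculus as the target, in the writhing test, at a dose of 50 mg/kg by the oral route; a higher number here means more inhibition at the dose given (going by the name of the read-out), a lower number less inhibition. Compound 1 `O=c1oc2ncccc2n1CCN1CCN(c2cccc(C(F)(F)F)c2)CC1` gives 10% and compound 2 `O=c1oc2ncccc2n1CCN1CCC(c2ccccc2)CC1` gives 9% in this assay. Compound 3 `O=c1oc2ncccc2n1CCCN1CCN(c2ccccc2)CC1` stands highest of the three in this assay at 98%, a difference beyond the scatter against both compound 1 and compound 2. Compound 4 `O=c1oc2ncccc2n1CCCN1CCN(c2ccc(F)cc2)CC1` is the next compound to be measured. It differs from compound 3 in one place: fluoro in place of hydrogen on an aromatic carbon. Among the measured compounds shown here, no measured pair shows what this change does here, so the expectation rests on compound 3 alone. Because compound 3 gives 98%, compound 4 is expected to stay near that level, with a step of a number 13 percentage points lower from compound 3 to compound 4 (beyond the scatter) that is small or none beyond the scatter. Compound 4 is therefore estimated at 85%, within a range of 55% to 100%.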

Compound 4, a percentage reported as inhibition, in the whole organism at one dose (the size of the read-out at that dose, not a potency): 85%
Beside the measured number, compound 4's estimate shows no gap at the digits printed; the range from low to high includes it.
By their numbers in this assay, from the lowest: compounds 2 and 1 (each within the scatter of the next); then compound 4; then compound 3.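

In this assay, the change from phenyl to 4-fluorophenyl gives a number 13 percentage points lower from compound 3 to compound 4 (beyond the scatter), the first measured effect of a change at this position. The step is modest, and compound 4 keeps a high number at 85%, so this position takes fluoro with some loss but not a collapse. Nothing measured here explains the drop.

Open, on these data alone, is whether chloro or methoxy at this same place would give a number closer to that of compound 3. Also open, as far as these compounds go, is how fluoro would behave on another carbon of this ring.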